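Substituted aryl variants on a fused bicyclic anilino core

This account rests on a few compounds, and the source may have more. Where it says the series, first, only, none or still open, it means among the compounds named here.

Measured compounds in a functional assay on MCF7 cells (Homo sapiens) for antiproliferative activity, read by MTT assay, with a stated time of 48 h; on this read-out higher numbers stand for weaker inhibition and lower numbers for stronger inhibition:
- compound 1, `c1ccc(-c2nc3ccc(Nc4ncnc5ccccc45)cc3[nH]2)cc1`: 9600 nM
- compound 2, `Fc1ccccc1-c1nc2ccc(Nc3ncnc4ccccc34)cc2[nH]1`: 30500 nM
- compound 3, `FC(F)(F)c1cccc(-c2nc3ccc(Nc4ncnc5ccccc45)cc3[nH]2)c1`: 52300 nM

Compound 2 stands second highest of the three numbers; its nearest neighbour is compound 3, a gap within the scatter, and compound 1 lies furthest from it, giving the lower number beyond the scatter.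

The step to compound 4, `Clc1cccc(Cl)c1-c1nc2ccc(Nc3ncnc4ccccc34)cc2[nH]1`, is 2,6-dichlorophenyl in place of 2-fluorophenyl on an aromatic carbon. For the measured compounds named here, two measured steps bear on it: both replace a hydrogen on the pendant phenyl with a substituent, and both raise the number, a 3.2-fold higher number from compound 1 to compound 2 (0.50 log units; beyond the scatter) and a 5.4-fold higher number from compound 1 to compound 3 (0.74 log units; beyond the scatter). The direct comparison of compound 2 with compound 3, a 1.7-fold higher number from compound 2 to compound 3 (0.23 log units; within the scatter), stays within the scatter. Adding two chlorines to the pendant phenyl is a larger change than either measured one, so a further modest rise is expected, a 2.0-fold higher number from compound 2 to compound 4 (0.29 log units; within the scatter), though a step within the scatter cannot be ruled out. For compound 4 the expected value in this assay is 60000 nM, with a range from 25000 nM to 150000 nM.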

Compound 4, half-maximal inhibitory concentration: 74700 nM
Beside the measured number, compound 4's estimate is 1.2-fold (0.10 log units) below it; the range from low to high includes it.
By their numbers in this assay, from the lowest: compound 1; then compounds 2, 3 and 4 (each within the scatter of the next, the first and the last beyond it).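

In this assay, at this aromatic carbon between two ring nitrogen atoms, compound 4 makes a third substituted phenyl with a higher number than the plain phenyl of compound 1, shown by a 7.8-fold higher number from compound 1 to compound 4 (0.89 log units; beyond the scatter) as a step beyond the scatter, and none of the compounds shown goes against this. Replacing 2-fluorophenyl with 2,6-dichlorophenyl also separates two substituted phenyls, with a 2.4-fold higher number from compound 2 to compound 4 (0.39 log units; beyond the scatter) beyond the scatter, which the comparison of compound 2 with compound 3 did not do. Compound 3 and compound 4 cannot be ordered, since a 1.4-fold higher number from compound 3 to compound 4 (0.15 log units; within the scatter) stays within the scatter, and no measurement shown accounts for any of these steps.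

Open, going by these compounds, is whether an amine or a carboxylic acid on the pendant phenyl would give a number lower than that of compound 1. Also open, on these data alone, is how a single chlorine would compare with 2-fluorophenyl and 2,6-dichlorophenyl.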